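A few compounds are considered here, and "the series" means these few. Any claim that something is new, unique, unknown or untested is made for them only; others in the source may bear on it.

Compound 1 `CC(C)NC(=O)c1ccc(C#Cc2ccccc2)nc1` is the reference point: in a functional assay on HEK293 cells for positive allosteric modulation of metabotropic glutamate receptor 5 (Homo sapiens), read by FLIPR and calcium flux (a lower number here means that less compound is needed, a higher number that more compound is needed for the effect), compound 1 gives 62 nM. Compound 2 `CN1CCc2nc(C#Cc3cccnc3)ccc2C1=O`, with a methyl on the amide-type nitrogen in a ring of its core, is reported in this assay as "not active" (no number reported), so no single number stands for compound 2 there. Compound 3 `CC(C)N1CCc2nc(C#Cc3cccnc3)ccc2C1=O` differs from compound 2 by isopropyl in place of methyl on an amide-type nitrogen in a ring. Among the measured compounds shown here, no measured step of this kind is at hand, and compound 2 has no value to step from; the isopropyl amide of compound 1 is the only pointer. Compound 3 is expected to regain some activity, estimated at 600 nM within a range of 100 nM to 5000 nM, though an inactive result remains quite possible.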

Compound 3, half-maximal effective concentration: "not active" (no number reported)
Compound 3: no number reported; the estimate stays without a comparison.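

Compound 2 and compound 3 are both reported as not active without a number, and no step can be read between them. The compounds shown leave open whether any other group on that amide-type nitrogen in a ring would give measurable activity. Nothing shown bears on this result.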